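The compounds below may be only part of what the source reports. "The series", "measured", "known", "first", "only" and "open" are said of these compounds alone.

Measured so far:
- Compound 1 `COc1ccc(NS(=O)(=O)/C=C/c2ccccc2OC)cc1`: 5000 nM
- Compound 2 `COc1ccc(/C=C/S(=O)(=O)Nc2ccc(OC)cc2)cc1`: 5000 nM

Within the data shown here, in a functional assay on K562 cells (Homo sapiens) for cytotoxicity, read by trypan blue exclusion, with a stated time of 96 h (on this read-out lower numbers stand for stronger inhibition and higher numbers for weaker inhibition), compound 2 gives 5000 nM and stands level with compound 1, the only other compound measured, with no difference beyond the scatter of repeat measurements. The next compound to be tested is compound 3 `COc1ccc(NS(=O)(=O)/C=C/c2ccc(OC)cc2OC)cc1`. Its structure differs from that of compound 2 by one change, methoxy in place of hydrogen on an aromatic carbon, ortho to a large group and meta to a methoxy group. Among the measured compounds shown here, no measured step shows what such a change does, so the size of this one has to be judged with little support. In this assay, no step beyond the scatter is expected, with only a slight lean towards stronger inhibition. The expected change is a 1.4-fold lower number from compound 2 to compound 3 (0.15 log units; within the scatter). For compound 3, the estimated value is 3500 nM, within an expected range of 1000 nM to 10000 nM.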

Compound 3, half-maximal inhibitory concentration: 15000 nM
Compound 3: middle estimate off by 4.3-fold (0.63 log units), on the low side; measured number above the stated range.
By their numbers in this assay, from the lowest: compounds 1 and 2 (each within the scatter of the next); then compound 3.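

In this assay, methoxy in place of hydrogen on an aromatic carbon, ortho to a large group and meta to a methoxy group, gives a 3.0-fold higher number from compound 2 to compound 3 (0.48 log units; beyond the scatter), so this added group weakens inhibition beyond the scatter. Seen from compound 1, the same kind of change at a different carbon of that ring gives a 3.0-fold higher number from compound 1 to compound 3 (0.48 log units; beyond the scatter), so a second methoxy on this ring raises the number, although compounds 1 and 2, with their single methoxy groups at different carbons, stand level. No measurement here offers a reason for this rise.

The compounds shown leave open whether the rise belongs to methoxy itself or would also follow a smaller group such as fluorine or hydroxyl at this carbon. They also leave open whether an amine there would bring the number back down.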